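Removing One Trifluoromethyl From the Urea Aryl Tail

The source may report more compounds than this note shows. Statements on the series, on what has been measured and on what is new or still open speak of the compounds shown alone.

Three ureas with a shared core were examined in a functional assay on ACHN cells (Homo sapiens) for inhibition, read by sulforhodamine B assay, with a stated time of 48 h, tested at 0.1 uM; a higher number here means a weaker effect of the compound at the concentration tested, a lower number a stronger effect. Compound 1 `O=C(Nc1cccc(-n2cc(-c3ccncc3)c(-c3cc(O)cc(Cl)c3)n2)c1)Nc1ccc(Cl)c(Cl)c1` gives 95% there. Compound 2 `COc1cc(Cl)cc(-c2nn(-c3cccc(NC(=O)Nc4ccc(Cl)c(C(F)(F)F)c4)c3)cc2-c2ccncc2)c1` gives 57% in this assay. Compound 3 `COc1cc(Cl)cc(-c2nn(-c3cccc(NC(=O)Nc4cc(C(F)(F)F)cc(C(F)(F)F)c4)c3)cc2-c2ccncc2)c1` gives 99%, the highest of the three numbers; compound 1 lies within the scatter of it, whereas compound 2 sits beyond the scatter, well below it. Compound 4 `COc1cc(Cl)cc(-c2nn(-c3cccc(NC(=O)Nc4cccc(C(F)(F)F)c4)c3)cc2-c2ccncc2)c1` differs from compound 3 by hydrogen in place of trifluoromethyl on an aromatic carbon. Among the compounds with values here, no pair of measured compounds that differ in only one place is available, so the size of this step has no direct precedent. A small downward step is expected, one that may well stay within the scatter, given that compound 3 shows 99%. Compound 4 is estimated at 87%, in a range from 60% to 100%, an expected step of a number 12 percentage points lower from compound 3 to compound 4 (beyond the scatter).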

Compound 4, a percentage reported as activity, at one concentration (the size of the read-out at that concentration, not a potency): 92%
Compound 4: the middle estimate sits 5 percentage points below what was measured, and the stated range covers the measured number.
By their numbers in this assay, from the lowest: compound 2; then compounds 4, 1 and 3 (each within the scatter of the next).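

In this assay, hydrogen in place of trifluoromethyl on an aromatic carbon gives a number 7 percentage points lower from compound 3 to compound 4 (within the scatter), so this change does not move the read-out beyond the scatter. Hydrogen in place of chloro on an aromatic carbon gives a number 35 percentage points higher from compound 2 to compound 4 (beyond the scatter), a large step beyond the scatter. Within the data shown here, these two steps give the first direct comparisons, and only the loss of chloro shifts the read-out clearly, toward a weaker effect at the concentration tested.

As far as these compounds go, whether a fluoro, bromo or methyl group in place of that chloro would keep the stronger effect of compound 2 remains open. Nothing shown explains why the two steps differ in size.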